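A few compounds are considered here, and "the series" means these few. Any claim that something is new, unique, unknown or untested is made for them only; others in the source may bear on it.

Values in an ADME assay on MDCK cells (Canis lupus familiaris) for cytotoxicity, read by microscopy, with a stated time of 48 h (on this read-out lower numbers stand for higher toxicity in this test and higher numbers for lower toxicity in this test), for the measured members of the series:

- compound 1, `C[C@H]1[C@H](NCc2ccsc2)C[C@H]2C[C@@H]1C2(C)C`: 50000 nM
- compound 2, `Cc1n[nH]cc1CN[C@@H]1C[C@H]2C[C@@H]([C@H]1C)C2(C)C`: reported only as a limit of the assay, > 100000 nM
- compound 3, `C[C@H]1[C@H](NCc2ccco2)C[C@H]2C[C@@H]1C2(C)C`: 50000 nM

Compound 3 stands level with compound 1 at the digits given; the step of no change at the digits printed from compound 1 to compound 3 (within the scatter) is within the scatter. The value of compound 2 is a limit, not a number (the limit of > 100000 nM in this assay, at which 1 of the 3 values shown sits), so the steps of an at least 2.0-fold higher number from compound 1 to compound 2 (0.30 log units; that floor lies within the scatter) and an at least 2.0-fold lower number from compound 2 to compound 3 (0.30 log units; that floor lies within the scatter) are floors only and each floor lies within the scatter. On the numbers shown, compound 3 is therefore indistinguishable from compound 1, and compound 2 may or may not differ from either.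

The next compound, compound 4, is `C[C@H]1[C@H](NCc2nccs2)C[C@H]2C[C@@H]1C2(C)C`. It differs from compound 3 in one place: 1,3-thiazol-2-yl in place of furan-2-yl on a saturated chain carbon bound to an amine nitrogen.

Among the measured compounds shown here, the only fully numbered step in the set, no change at the digits printed from compound 1 to compound 3 (within the scatter), also swaps one five-membered aromatic ring for another on the saturated chain carbon bound to the amine nitrogen and gave no change. The steps involving compound 2 swap in a different ring but end at the limit and so set no size. A step of no more than the scatter is therefore expected, a 1.2-fold higher number from compound 3 to compound 4 (0.08 log units; within the scatter), in no particular direction. For compound 4 the expected value in this assay is 60000 nM, with a range from 25000 nM to 100000 nM, and a fair chance that only a limit is reported.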

Compound 4, minimum cytotoxic concentration: > 100000 nM
Compound 4: no number, only a limit; the forecaster's own chance of this, stated with the estimate: 40%; middle value at least 1.6-fold (0.22 log units) away from the limit.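

In this assay compound 4, with 1,3-thiazol-2-yl on a saturated chain carbon bound to an amine nitrogen, is reported only as a limit of > 100000 nM and is the second ring at this place, after 3-methyl-1H-pyrazol-4-yl in compound 2, to end there, so reaching the limit is not confined to one group: the limit of > 100000 nM in this assay, at which 2 of the 4 values shown sit.
The readable steps of an at least 2.0-fold higher number from compound 3 to compound 4 (0.30 log units; that floor lies within the scatter) and an at least 2.0-fold higher number from compound 1 to compound 4 (0.30 log units; that floor lies within the scatter) are floors only, so the 1,3-thiazol-2-yl change is not shown to differ from furan-2-yl or thiophen-3-yl, nor is it shown to match them.
The steps between the two limits cannot be read, which leaves compound 2 and compound 4 unordered.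

Going by these compounds, it remains open how far compound 2 and compound 4 lie past the limit, and whether any ring change at this place moves the read-out beyond the scatter. Also open, on these data alone, is what a group of another kind would give here, such as a phenyl ring, a carboxylic acid, or a longer chain between the ring and the amine nitrogen.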